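Working notes: methyl added to compound 1, giving compound 4

The compounds below may be only part of what the source reports. "The series", "measured", "known", "first", "only" and "open" are said of these compounds alone.

Measured in a functional assay on MCF7 cells (Homo sapiens) for cytotoxicity, read by MTT assay, with a stated time of 72 h; on this read-out higher numbers stand for weaker inhibition and lower numbers for stronger inhibition:
compound 1 `O=c1cc(CSc2nc3ccccc3s2)oc2ccccc12` — > 25000 nM
compound 2 `Cc1nnc(SCc2cc(=O)c3cc(Cl)ccc3o2)o1` — > 25000 nM
compound 3 `COC(=O)Nc1ccc2c(CSc3nc(C)cc(C)n3)cc(=O)oc2c1` — 9900 nM

Compound 1 gives no number in this assay; its value > 25000 nM is a limit of the assay. Compound 2 likewise sits at a limit, > 25000 nM. Compound 3 is the only one of the three with a numeric read-out, 9900 nM. Compound 1 therefore stands at the limit of > 25000 nM in this assay, at which 2 of the 3 values shown sit, and nothing places it relative to compound 2 beyond that shared limit.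

Within the data shown here, no two measured compounds differ in a single place, so no measured step is available for sizing the change to compound 4 `Cc1ccc2oc(CSc3nc4ccccc4s3)cc(=O)c2c1`. The difference from compound 1 is methyl in place of hydrogen on an aromatic carbon. Among the measured compounds shown here, with compound 1 already at the assay limit and no comparable step known, the expected step is none beyond the usual scatter, a step that the limit leaves unreadable from compound 1 to compound 4. Compound 4 is therefore estimated at 30000 nM, with a range from 10000 nM to 100000 nM, and it is expected that this assay will most likely again report only a limit for compound 4 rather than a number.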

Compound 4, half-maximal inhibitory concentration: > 25000 nM
Compound 4: a limit, no number; the forecaster's own chance of this, stated with the estimate: 70%; the middle value does not contradict the limit.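

No step can be read from compound 1 to compound 4 in this assay, as both results are limits of the assay and not numbers: the limit of > 25000 nM in this assay, at which 3 of the 4 values shown sit.

The compounds shown leave open whether methyl in place of hydrogen on an aromatic carbon of the shared core changes the read-out at all.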